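The source may report more compounds than this note shows. Statements on the series, on what has been measured and on what is new or still open speak of the compounds shown alone.

Compound 2 `CCS(=O)(=O)Nc1cc(-c2ccc3ncnc(Nc4ccc(OC(F)(F)F)cc4)c3c2)cnc1OC` stands highest of the three numbers in a functional assay on HCT-116 cells (Homo sapiens) for cytotoxicity, read by sulforhodamine B assay, with a stated time of 72 h (a lower number here means a stronger inhibitor, a higher number a weaker inhibitor), giving 16600 nM. Compound 1 `CCS(=O)(=O)Nc1cc(-c2ccc3ncnc(Nc4ccc(F)cc4)c3c2)cnc1OC` gives 3160 nM in this assay, and compound 3 `CCS(=O)(=O)Nc1cc(-c2ccc3ncnc(Nc4ccc(OC)c(OC)c4)c3c2)cnc1OC` gives 4360 nM. The steps read a 5.3-fold higher number from compound 1 to compound 2 (0.72 log units; beyond the scatter), a 3.8-fold lower number from compound 2 to compound 3 (0.58 log units; beyond the scatter) and a 1.4-fold higher number from compound 1 to compound 3 (0.14 log units; within the scatter). Compound 4 `CCS(=O)(=O)Nc1cc(-c2ccc3ncnc(Nc4cccc(C(=O)OC)c4)c3c2)cnc1OC` differs from compound 2 by 3-(methoxycarbonyl)phenyl in place of 4-(trifluoromethoxy)phenyl on a nitrogen on an aromatic ring. Among the measured compounds shown here, both measured exchanges of the group on the nitrogen on the aromatic ring, starting from compound 2, gave modest lower numbers, and the move to another substituted phenyl is therefore expected to give a modest lower number as well, with the caution that no measured step carries the entering group. For compound 4 the expected step is a 3.3-fold lower number from compound 2 to compound 4 (0.52 log units; beyond the scatter). Compound 4 is estimated at 5000 nM, with a range of 2000 nM to 13000 nM.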

Compound 4, half-maximal inhibitory concentration: 400 nM
Compound 4: middle estimate off by 13-fold (1.10 log units), on the high side, outside the stated range (below it).
By their numbers in this assay, from the lowest: compound 4; then compounds 1 and 3 (each within the scatter of the next); then compound 2.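

On the nitrogen on the aromatic ring, 3-(methoxycarbonyl)phenyl reaches a lower range in this assay than the three earlier groups, with a 42-fold lower number from compound 2 to compound 4 (1.62 log units; beyond the scatter), an 11-fold lower number from compound 3 to compound 4 (1.04 log units; beyond the scatter) and a 7.9-fold lower number from compound 1 to compound 4 (0.90 log units; beyond the scatter). Among compound 1, compound 2 and compound 3, no step was large, so this position allows a larger change than they showed, and compound 4 now stands as the strongest of the four. Nothing measured here accounts for the gain. Still open, as far as these compounds go, is whether the methoxycarbonyl group itself carries the step, and how a carboxylic acid or an amide in its place on the phenyl would read.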